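Carbonyl substituent variation: working notes on compounds 1 to 4

The source may hold more compounds than are shown below. What is called first, only, known or untested is meant among the compounds shown, and "the series" means these compounds.

Measured so far:
compound 1 `COc1cc(-c2nnc3n2NC(c2ccco2)C(C(=O)c2ccco2)S3)cc(OC)c1OC` — > 100000 nM, a limit of the assay
compound 2 `COc1ccc(C(=O)C2Sc3nnc(-c4cc(OC)c(OC)c(OC)c4)n3NC2c2ccco2)cc1` — > 100000 nM, a limit of the assay
compound 3 `COc1cc(-c2nnc3n2NC(c2ccco2)C(C(=O)c2cccs2)S3)cc(OC)c1OC` — 64100 nM

Among the compounds with values here, in a functional assay on HepG2 cells (Homo sapiens) for cytotoxicity, read by MTT assay, with a stated time of 48 h (on this read-out lower numbers stand for stronger inhibition and higher numbers for weaker inhibition), compound 3 gives the only number in the set, 64100 nM. Compound 1 sits at the assay's limit with > 100000 nM. Compound 2 likewise sits at the limit with > 100000 nM. Both therefore stand at the limit of > 100000 nM in this assay, at which 2 of the 3 values shown sit.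

Compound 4 `COc1cc(-c2nnc3n2NC(c2ccco2)C(C(=O)c2ccc(Br)cc2)S3)cc(OC)c1OC` differs from compound 3 by 4-bromophenyl in place of thiophen-2-yl on a carbonyl carbon. Within the data shown here, the steps that bear on this are the two ending in compound 3: an at least 1.5-fold lower number from compound 1 to compound 3 (0.19 log units; that floor lies within the scatter) and an at least 1.5-fold lower number from compound 2 to compound 3 (0.19 log units; that floor lies within the scatter). Their true size is hidden because the limit of > 100000 nM in this assay, at which 2 of the 3 values shown sit, caps the starting values, so only a floor is readable, and that floor lies within the scatter. The change into compound 4 runs the other way: thiophen-2-yl leaves, a six-membered carbon-only ring enters, as in compound 2, which sits at the limit. A rise in the number, possibly back to the limit, is therefore expected, though the evidence does not fix its size.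

Compound 4 is estimated at 110000 nM, within 40000 nM to 300000 nM, which means an expected step of a 1.7-fold higher number from compound 3 to compound 4 (0.23 log units; within the scatter).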

Compound 4, half-maximal inhibitory concentration: > 100000 nM
Compound 4 ended at the assay's limit; the forecaster's own chance of this, stated with the estimate: 55%; the middle value is on the limit's open side.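

In this assay the exchange of thiophen-2-yl for 4-bromophenyl on the carbonyl carbon reads as an at least 1.5-fold higher number from compound 3 to compound 4 (0.19 log units; that floor lies within the scatter). The steps to compound 4 from compound 1 and from compound 2 cannot be read. After 4-methoxyphenyl in compound 2, 4-bromophenyl in compound 4 is a second six-membered aromatic ring of carbon only on the carbonyl carbon to end at the limit, though furan-2-yl in compound 1, a five-membered ring, goes against any split by ring size: the limit of > 100000 nM in this assay, at which 3 of the 4 values shown sit.

Going by these compounds, how far compound 1, compound 2 and compound 4 lie past that limit stays open, so no order can be set among them. Also open, on these data alone, is whether an amine or a carboxylic acid in place of the bromo group on that phenyl ring would give a readable number.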